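The source may report more compounds than this note shows. Statements on the series, on what has been measured and on what is new or still open speak of the compounds shown alone.

Among the measured compounds shown here, compound 1 `Cc1ccc(-n2c(=O)n(-c3ccc(C#N)c(C(F)(F)F)c3)c3ccccc32)cc1` is the only compound with a full number in a physicochemical assay for solubility; on this read-out lower numbers stand for lower solubility and higher numbers for higher solubility: in this assay compound 1 gives 790 nM. Compound 2 `N#Cc1ccc(-n2c(=O)n(Cc3ccccc3)c3cccnc32)cc1C(F)(F)F` is reported in this assay only as a limit, < 500 nM, and that limit of < 500 nM in this assay, at which 1 of the 2 values shown sits, is where one of the two recorded values sits. Compound 3 `N#Cc1ccc(-n2c(=O)n(Cc3ccccn3)c3ccccc32)cc1C(F)(F)F` has not yet been measured; it carries (pyridin-2-yl)methyl in place of 4-methylphenyl on an aromatic nitrogen. For the measured compounds named here, no measured pair differs in a single place, so no step size is known. The step from compound 1 to compound 3 is expected to be a modest gain in this assay, a 1.9-fold higher number from compound 1 to compound 3 (0.28 log units; within the scatter). Compound 3 is expected to give 1500 nM, with a likely range from 500 nM to 4500 nM.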

Compound 3, solubility: 12000 nM
Compound 3: middle estimate off by 8.0-fold (0.90 log units), on the low side, and the stated range ends below it.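

In this assay, putting (pyridin-2-yl)methyl in place of 4-methylphenyl on an aromatic nitrogen gives a 15-fold higher number from compound 1 to compound 3 (1.18 log units; beyond the scatter). Among the compounds shown here, this is the first readable step, and it shows that this position can move the read-out well beyond the scatter, even though both groups have the same count of heavy atoms. Nothing measured here explains the rise.

The new group differs in two ways at once, a ring nitrogen and an added methyl-derived carbon, and the effects of these remain unseparated. Going by these compounds, how a longer chain ending in an amine, or a carboxylic acid, would read at this position stays open.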